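The source may report more compounds than this note shows. Statements on the series, on what has been measured and on what is new or still open speak of the compounds shown alone.

The series shares the core of compound 1 `COc1ccc2nc(C)cc(OCC(=O)Nc3cc(C)ccc3C)c2c1`, with an aryl amide attached through the amide-type nitrogen. In a toxicity assay on HepG2 cells (Homo sapiens) for inhibition, read by CellTiter-Glo, with a stated time of 48 h (a lower number here means a stronger inhibitor, a higher number a weaker inhibitor), compound 1 gives > 100000 nM, which is a limit of the assay rather than a number. Compound 2 `COc1ccc2nc(C)cc(OCC(=O)Nc3c(C)cccc3C)c2c1` carries 2,6-dimethylphenyl in place of 2,5-dimethylphenyl on that nitrogen. In this assay compound 2 gives > 100000 nM, again a limit and not a number. The step that the two limits leave unreadable from compound 1 to compound 2 cannot be sized, since both values sit at the limit of > 100000 nM in this assay, at which 2 of the 2 values shown sit. Compound 2 thus stands only at a limit, with no measured number to place it against.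

Compound 3 `COc1cccc(NC(=O)COc2cc(C)nc3ccc(OC)cc23)c1` is the next member: 3-methoxyphenyl in place of 2,6-dimethylphenyl on an amide-type nitrogen. Among the compounds with values here, no measured step bears directly on an exchange of this kind; the single step in hand, a step that the two limits leave unreadable from compound 1 to compound 2, is itself unreadable, and both values rest on (the limit of > 100000 nM in this assay, at which 2 of the 2 values shown sit). The expectation is that compound 3 also fails to reach a measurable value, a step of a number no higher from compound 2 to compound 3 (the limit leaves the size open) that is not expected to exceed the scatter. Compound 3 is estimated at 100000 nM, with a range from 30000 nM to 300000 nM, most likely reported only as a limit.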

Compound 3, half-maximal inhibitory concentration: > 100000 nM
Compound 3 was reported as a limit; the forecaster's own chance of this, stated with the estimate: 75%; the middle value lies on the limit itself.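

In this assay compound 3 gives > 100000 nM, again a limit and not a number. No new step among compound 1, compound 2 and compound 3 can be read, since all three values rest on the same limit: the limit of > 100000 nM in this assay, at which 3 of the 3 values shown sit.

The compounds shown leave open whether any aryl amide on the shared core reaches a measurable value in this assay.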